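Trading a Hydroxylated Branch for a Thioether Chain

The compounds below may be only part of what the source reports. "The series", "measured", "known", "first", "only" and "open" are said of these compounds alone.

Of the compounds shown here, two sharing one core have been measured in a functional assay on HT cells (Homo sapiens) for antiproliferative activity, read by fluorescence, with a stated time of 72 h; a lower number here means a stronger inhibitor of growth, a higher number a weaker inhibitor of growth. Compound 1 `CC(O)CSc1nc(NCc2ccc(-c3ccccn3)cc2)c2[nH]nc(C(C)C)c2n1` gives 62 nM in this assay, and compound 2 `CC(C)c1n[nH]c2c(NCc3ccc(-c4ccccn4)cc3)nc(SC(C)C(C)O)nc12` gives 190 nM. For the measured compounds named here, compound 2 thus stands at the higher of the two numbers, the weaker inhibitor of growth of the pair, and the step of a 3.1-fold higher number from compound 1 to compound 2 (0.49 log units; beyond the scatter) is the only change measured so far.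

Compound 3 `CSCCSc1nc(NCc2ccc(-c3ccccn3)cc2)c2[nH]nc(C(C)C)c2n1` has not yet been tested. Its difference from compound 2 is 2-(methylsulfanyl)ethyl in place of 2-hydroxy-1-methylpropyl on a sulfur. Going by the values given here, only one measured step bears on this: a 3.1-fold higher number from compound 1 to compound 2 (0.49 log units; beyond the scatter), in which methyl took the place of hydrogen on a saturated chain carbon bound to a saturated chain carbon and a sulfur. Compound 3 has no such methyl, so on that evidence the number would be expected to move back toward compound 1. Nothing measured speaks to the exchange of the hydroxyl for the methylsulfanyl group, which leaves the estimate uncertain. Compound 3 is therefore expected to show a 2.4-fold lower number from compound 2 to compound 3 (0.38 log units; beyond the scatter), with an estimated value of 80 nM and a range from 30 nM to 250 nM.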

Compound 3, concentration for 50% growth inhibition: 975 nM
Beside the measured number, compound 3's estimate is 12-fold (1.09 log units) below it; measured number above the stated range.
By their numbers in this assay, from the lowest: compound 1; then compound 2; then compound 3.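

The thioether chain gives a far weaker result at this position than either hydroxylated chain: in this assay, replacing 2-hydroxy-1-methylpropyl with 2-(methylsulfanyl)ethyl on the sulfur gives a 5.1-fold higher number from compound 2 to compound 3 (0.71 log units; beyond the scatter), even though the methyl that separated compound 1 from compound 2 is gone. The closer comparison with the unbranched compound 1, in which (methylsulfanyl)methyl takes the place of 1-hydroxyethyl on a saturated chain carbon bound to a sulfur, gives a 16-fold higher number from compound 1 to compound 3 (1.20 log units; beyond the scatter), so removing the branch does not by itself restore the number, and the outer part of the chain matters here at least as much as its branching. Nothing available explains why this exchange weakens growth inhibition.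

The three compounds leave open whether the rise in the number follows from losing the hydroxy group or from gaining the methylsulfanyl group, as both changes occur together in compound 3. A methoxy group, an amine or a carboxylic acid at the end of the same chain, or a longer chain ending in hydroxy, would help separate these two readings.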